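The compounds below may be only part of what the source reports. "The series", "measured", "known", "first", "only" and "open" are said of these compounds alone.

Compound 3 `CCCCCCCC(=O)c1c(O)c(Cl)c(O)c(Cl)c1O` holds the lowest number of the three measured in a functional assay on the whole organism (S2 cells, strain S2) for inhibition, with Drosophila as the target, read by a luciferase reporter, with stated times of 1.5 h and 8 h; on this read-out higher numbers stand for weaker inhibition and lower numbers for stronger inhibition: compound 3 gives 3700 nM, whereas compound 1 `CCCC(=O)c1c(O)c(Cl)c(O)c(Cl)c1O` gives 21500 nM and compound 2 `CCCCCC(=O)c1c(OC)c(Cl)c(OC)c(Cl)c1OC` gives 18900 nM. Compound 4 `CCCCCCCCC(=O)c1c(O)c(Cl)c(O)c(Cl)c1O` has not yet been measured; it differs from compound 3 by methyl in place of hydrogen on a saturated chain carbon, seven bonds along the chain from a carbonyl carbon. For the measured compounds named here, the one measured step that bears on this change is an earlier lengthening of the same chain, a 5.8-fold lower number from compound 1 to compound 3 (0.76 log units; beyond the scatter). Compound 4 adds only a methyl at the end of that chain, a much smaller change than the butyl of that step, so only a small further drop, probably within the scatter, is expected in this assay. The expected step is a 1.3-fold lower number from compound 3 to compound 4 (0.12 log units; within the scatter). Compound 4 is therefore estimated to give about 2800 nM, within a range of 1200 nM to 6500 nM.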

Compound 4, half-maximal inhibitory concentration: 6500 nM
Compound 4: the middle estimate sits 2.3-fold (0.37 log units) below what was measured; measured number inside the range.
By their numbers in this assay, from the lowest: compounds 3 and 4 (each within the scatter of the next); then compounds 2 and 1 (each within the scatter of the next).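

In this assay, methyl in place of hydrogen at this chain carbon, seven bonds along the chain from the carbonyl carbon, gives a 1.8-fold higher number from compound 3 to compound 4 (0.24 log units; within the scatter), so this extension cannot be told apart from the chain it extends. The larger change, pentyl in place of hydrogen three bonds along the chain, still gives a 3.3-fold lower number from compound 1 to compound 4 (0.52 log units; beyond the scatter). Nothing here explains these numbers.

Going by these compounds, whether a longer chain would hold this level or lose it remains open. So does the effect of an amine or a carboxylic acid on the chain.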